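From Isobutyl to Phenyl on the Amino Acid Carbon

The compounds below may be only part of what the source reports. "The series", "measured", "known", "first", "only" and "open" are said of these compounds alone.

Three compounds share one core and differ only at a saturated chain carbon bound to an amide-type nitrogen and a carbonyl carbon. Compound 1 `CCCCCCCCC(CCCCCCCCC(=O)OC)SCC(=O)NCC(=O)OC` has hydrogen there; in a functional assay on MDA-MB-231 cells (Homo sapiens) for cytotoxicity, read by MTT assay (a higher number here means a weaker inhibitor, a lower number a stronger inhibitor), compound 1 gives 31400 nM. Compound 2 `CCCCCCCCC(CCCCCCCCC(=O)OC)SCC(=O)N[C@H](C(=O)OC)[C@@H](C)CC` carries a sec-butyl at that carbon, and in this assay compound 2 gives 22400 nM, so the step of a 1.4-fold lower number from compound 1 to compound 2 (0.15 log units; within the scatter). Compound 3 `CCCCCCCCC(CCCCCCCCC(=O)OC)SCC(=O)N[C@@H](CC(C)C)C(=O)OC` carries an isobutyl, and in this assay compound 3 gives 152000 nM, the highest of the three numbers and therefore the weakest inhibitor shown, since the steps of a 4.8-fold higher number from compound 1 to compound 3 (0.68 log units; beyond the scatter) and a 6.8-fold higher number from compound 2 to compound 3 (0.83 log units; beyond the scatter) both lie beyond the scatter.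

Compound 4 `CCCCCCCCC(CCCCCCCCC(=O)OC)SCC(=O)N[C@H](C(=O)OC)c1ccccc1` differs from compound 3 by phenyl in place of isobutyl on a saturated chain carbon bound to an amide-type nitrogen and a carbonyl carbon. Within the data shown here, no measured step introduces a phenyl, so the only guide is that the two steps adding an isobutyl, from hydrogen or from sec-butyl, each raised the number modestly. Taking the isobutyl away again may give part of that back, but with a new group entering the expectation is held loosely: compound 4 is expected to show a 3.4-fold lower number from compound 3 to compound 4 (0.53 log units; beyond the scatter), a somewhat lower number. The estimate for compound 4 in this assay is 45000 nM, within a range from 15000 nM to 150000 nM.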

Compound 4, half-maximal inhibitory concentration: 38600 nM
Estimate against measurement, compound 4: 1.2-fold (0.07 log units) above; low and high end bracket the measured number.
By their numbers in this assay, from the lowest: compounds 2, 1 and 4 (each within the scatter of the next); then compound 3.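

Phenyl in place of isobutyl gives a 3.9-fold lower number from compound 3 to compound 4 (0.60 log units; beyond the scatter) and so brings the number back into the company of the other two compounds, with a 1.7-fold higher number from compound 2 to compound 4 (0.24 log units; within the scatter) and a 1.2-fold higher number from compound 1 to compound 4 (0.09 log units; within the scatter) both inside the scatter. In this assay, hydrogen, sec-butyl and phenyl at this saturated chain carbon therefore cannot be told apart, and compound 3 alone, with its isobutyl, stands out as the weakest of the four; phenyl brings 6 heavy atoms against the 4 of isobutyl, so the higher heavy-atom count does not go with a higher number here, and a six-membered aromatic ring is accepted at this carbon without a measurable loss compared with hydrogen. Nothing available explains why isobutyl alone departs from the others.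

On these data alone, whether that departure belongs to isobutyl alone remains open, since a longer chain such as n-hexyl or a benzyl group at the same carbon could fall with compound 3 or with the other three. An amine or a carboxylic acid on the side chain at this carbon would test the position with a kind of group that none of these four compounds carries.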